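The source may report more compounds than this note shows. Statements on the series, on what has been measured and on what is new or still open speak of the compounds shown alone.

Measured so far in an ADME assay on cells (Macrophage) for cytotoxicity, read by resazurin assay, with a stated time of 48 h; a higher number here means that more compound is tolerated, a lower number that less compound is tolerated:

compound 1 `CCCCCCn1cc(COc2ccc3c(c2)OC(c2ccccc2)CC3=O)nn1` - "not determined" (no result reported)
compound 2 `CCCCCCn1cc(COc2ccc3c(c2)OC(c2ccc(OC)cc2)CC3=O)nn1` - 57500 nM

Within the data shown here, compound 2 holds the only number. Compound 1 has no result, so compound 2 cannot yet be ranked against a neighbour, and its position says nothing about a trend.

The next compound to be read is compound 3 (`CCCCCCn1cc(COc2ccc3c(c2)OC(c2ccc(Br)cc2)CC3=O)nn1`). It carries bromo in place of methoxy on an aromatic carbon, para to a large group, which turns 4-methoxyphenyl into 4-bromophenyl. The counted difference is bromo in place of methoxy on an aromatic carbon and the rest of the structure is shared.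

Among the measured compounds shown here, no measured pair shows what this exchange does in this assay, so the data give no firm ground for a direction. No step beyond the scatter is expected, with only a slight lean towards less compound being tolerated. The expected step, a 1.4-fold lower number from compound 2 to compound 3 (0.16 log units; within the scatter), is an estimate anchored on compound 2 alone. For compound 3 the estimated half-maximal cytotoxic concentration is 40000 nM, with an expected range of 15000 nM to 100000 nM on repeat measurement.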

Compound 3, half-maximal cytotoxic concentration: 20300 nM
For compound 3 the middle estimate is 2.0-fold (0.29 log units) above the measured one, and the stated range covers the measured number.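

In this assay, the change from 4-methoxyphenyl to 4-bromophenyl gives the series its first readable step, a 2.8-fold lower number from compound 2 to compound 3 (0.45 log units; beyond the scatter), so the aromatic position para to a large group is not silent: with bromo in place of methoxy, less compound is tolerated. This rests on a single pair with the rest of the structure shared, so it describes this exchange on this background and sets no trend. Nothing at hand bears on why the number moves with this exchange.

On these data alone, compound 1 carries no number, so the steps to it cannot be read, and it remains open whether either substituent differs from the plain phenyl ring, or which of the two lies closer to it. The compounds shown also leave open how a fluoro group, an amine or a carboxylic acid at the same position would read, and thus whether the step follows from bromo itself or from the loss of methoxy.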